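Pentyl for chloro on the aryl ring of compound 1

The compounds below may be only part of what the source reports. "The series", "measured", "known", "first", "only" and "open" are said of these compounds alone.

Compound 1 `O=C1C2=C(C(=O)c3ncccc31)C1(CS2)NC(=O)N(c2ccc(Cl)cc2)C1=O`: 10 nM
Compound 2 `Cc1ccc(N2NC(=O)NC3(CSC4=C3C(=O)c3ncccc3C4=O)C2=O)cc1`: 37 nM

In a functional assay on CCRF-SB cells (Homo sapiens) for antiproliferative activity, read by MTT assay, with a stated time of 96 h (on this read-out higher numbers stand for weaker inhibition and lower numbers for stronger inhibition), compound 1 gives 10 nM, the lowest of the two numbers. Compound 2 gives 37 nM, a gap beyond the scatter. Compound 3 `CCCCCc1ccc(N2C(=O)NC3(CSC4=C3C(=O)c3ncccc3C4=O)C2=O)cc1` has not yet been measured in this assay. It differs from compound 1 in one place: pentyl in place of chloro on an aromatic carbon. Among the compounds with values here, no measured pair shows this change, so the step rests on compound 1 alone. The step of a 4.0-fold higher number from compound 1 to compound 3 (0.60 log units; beyond the scatter) is expected to be a moderate rise, with wide uncertainty. Compound 3 is expected to give 40 nM, within a range from 8 nM to 200 nM.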

Compound 3, half-maximal inhibitory concentration: 150 nM
Compound 3: middle estimate off by 3.8-fold (0.57 log units), on the low side; the range from low to high includes it.
By their numbers in this assay, from the lowest: compound 1; then compound 2; then compound 3.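

Pentyl in place of chloro brings a 15-fold higher number from compound 1 to compound 3 (1.18 log units; beyond the scatter) in this assay, the first measured step at this position. On an aromatic carbon para to a large group, the choice of substituent therefore matters strongly, and a five-carbon chain is not interchangeable with chloro on the core of compound 1. Nothing at hand explains this rise.

On these data alone, with one step, it remains open whether the rise tracks chain length, as an ethyl or butyl group could show. As far as these compounds go, it is also open how an amine or a carboxylic acid would fare at this position.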